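Swapping the Chain End of Compound 1

A few compounds are considered here, and "the series" means these few. Any claim that something is new, unique, unknown or untested is made for them only; others in the source may bear on it.

Compound 1 `CCOc1cc(C(C)(C)C)ccc1C1=NC(c2ccc(Cl)cc2)C(c2ccc(Cl)cc2)N1C(=O)NCCCCCCCC(=O)NO`: 5030 nM
Compound 2 `CCOc1cc(C(C)(C)C)ccc1C1=NC(c2ccc(Cl)cc2)C(c2ccc(Cl)cc2)N1C(=O)N1CCN(CCCCCCCC(=O)NO)CC1`: 1710 nM
Compound 3 `CCOc1cc(C(C)(C)C)ccc1C1=NC(c2ccc(Cl)cc2)C(c2ccc(Cl)cc2)N1C(=O)NCc1ccc(C(=O)NO)cc1`: 9100 nM

In a functional assay on HCT-116 cells (Homo sapiens) for antiproliferative activity, read by CCK-8 assay, with a stated time of 72 h (on this read-out lower numbers stand for stronger inhibition and higher numbers for weaker inhibition), compound 1 holds the middle of the three numbers. Compound 2 lies beyond the scatter on the lower side, and compound 3 lies within the scatter of compound 1.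

Compound 4 `CCOc1cc(C(C)(C)C)ccc1C1=NC(c2ccc(Cl)cc2)C(c2ccc(Cl)cc2)N1C(=O)NCCCCC(=O)Nc1ccccc1N` carries (2-aminophenyl)carbamoyl in place of 3-(hydroxycarbamoyl)propyl on a saturated chain carbon, four bonds along the chain from an amide-type nitrogen and keeps the shared core.

Among the measured compounds shown here, the one measured step that bears on this is a 1.8-fold higher number from compound 1 to compound 3 (0.26 log units; within the scatter) and it retains the hydroxycarbamoyl group. For the measured compounds named here, no measured compound carries the new group, so this guide is loose. No step beyond the scatter is expected in either direction.

In this assay the expected value for compound 4 is 6000 nM (estimated range 2000 nM to 18000 nM).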

Compound 4, half-maximal inhibitory concentration: 13900 nM
Compound 4: the middle estimate sits 2.3-fold (0.36 log units) below what was measured; measured number inside the range.
By their numbers in this assay, from the lowest: compound 2; then compounds 1, 3 and 4 (each within the scatter of the next, the first and the last beyond it).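

In this assay, replacing the chain end at this position now gives a change beyond the scatter, with a 2.8-fold higher number from compound 1 to compound 4 (0.44 log units; beyond the scatter), whereas the earlier step, which retained the hydroxycarbamoyl group, stayed within it. Thus, (2-aminophenyl)carbamoyl in place of 3-(hydroxycarbamoyl)propyl gives weaker inhibition, and the hydroxycarbamoyl group is not interchangeable with it here. No available evidence accounts for this difference. Left open is how a carboxylic acid at this chain end would read, and whether a longer chain carrying (2-aminophenyl)carbamoyl would change the number.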